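Replacing propanoyl with tert-butyl in compound 2

The source may report more compounds than this note shows. Statements on the series, on what has been measured and on what is new or still open speak of the compounds shown alone.

Among the compounds with values here, in an ADME assay on microsomes from liver (Rattus norvegicus, strain Sprague-Dawley) for metabolic stability, read by LC-MS, with a stated time of 15 min, tested at 20 uM (on this read-out lower numbers stand for a less stable compound and higher numbers for a more stable compound), compound 2 (`CCC(=O)c1ccccc1OC(=O)c1coc(-c2ccccc2)n1`) gives 8.7% and sits at the low end of the three numbers known so far. Compound 3 (`O=C(Oc1cccc2c1CCCC2)c1coc(-c2ccccc2)n1`) shares that low end, giving 14.5% and lying within the usual scatter of compound 2. Compound 1 (`Cc1ccn2c(C(=O)NCc3ccc(Cl)cc3)c(C)nc2c1`) stands far higher, at 80.7% after the same incubation.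

The next structure, compound 4 (`CC(C)(C)c1ccccc1OC(=O)c1coc(-c2ccccc2)n1`), differs from compound 2 in one place: tert-butyl in place of propanoyl on an aromatic carbon. Within the data shown here, no measured pair shows this change, so the expectation has to lean on a neighbour. Compound 2 shares part of its structure with compound 3, which has no propanoyl, yet compound 3 remains low at 14.5%, so losing propanoyl alone is not expected to bring much gain. In this assay a small rise is expected, an estimated a number 9.3 percentage points higher from compound 2 to compound 4 (within the scatter) that is not beyond the scatter. For compound 4 the estimate is 18% with an expected range from 5% to 50% in that same read-out.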

Compound 4, percent of the compound remaining: 6.9%
Compound 4: the middle estimate sits 11.1 percentage points above what was measured; low and high end bracket the measured number.
By their numbers in this assay, from the lowest: compounds 4, 2 and 3 (each within the scatter of the next); then compound 1.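

In this assay, putting tert-butyl in place of propanoyl on this aromatic carbon gives a number 1.8 percentage points lower from compound 2 to compound 4 (within the scatter), so the exchange does not separate the two compounds. Within the data shown here, this is the first direct look at this position: a group with a carbonyl and a hydrogen-bond acceptor gives way to an all-carbon group with no acceptor, and the read-out does not move beyond the usual scatter. Nothing available here gives a reason for this result.

Going by these compounds, what remains open is whether any group on this aromatic carbon can lift the number at all, for example an amine, a carboxylic acid or a longer chain. On these data alone, compound 2 and compound 4 also share the rest of their structure, so the effect of a change elsewhere in that shared part remains unknown.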